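The compounds below may be only part of what the source reports. "The series", "measured", "known", "first", "only" and "open" are said of these compounds alone.

Measured compounds in a functional assay on the whole organism (blood) with Rattus norvegicus as the target, with stated times of 24 h and 1 h, at a dose of 5 mg/kg by the intraperitoneal route; a higher number here means a stronger effect of the compound at the dose given, a lower number a weaker effect:
compound 1 `COc1ccc(Cl)cc1C(=O)NCC1CCN(S(=O)(=O)NC(=O)NC[C@@H]2C[C@@H]3C=C[C@@H]2C3)CC1`: 15%
compound 2 `COc1ccc(Cl)cc1C(=O)NCCC1CCN(S(=O)(=O)NC(=O)NC[C@@H]2C[C@@H]3CC[C@@H]2O3)CC1`: 30%
compound 3 `Cc1cccc(C(=O)NCCC2CCN(S(=O)(=O)NC(=O)NC[C@@H]3C[C@@H]4C=C[C@@H]3C4)CC2)n1`: 20%

Among these three, compound 3 gives a number that differs from that of compound 1 and from that of compound 2 by no more than the usual scatter of repeated measurements, so the three stand together rather than apart. Compound 4 `O=C(NC[C@@H]1C[C@@H]2C=C[C@@H]1C2)NS(=O)(=O)N1CCC(CCNC(=O)c2ccc3ccccc3n2)CC1` has not yet been measured. It differs from compound 3 in one place: quinolin-2-yl in place of 6-methylpyridin-2-yl on a carbonyl carbon. Among the measured compounds shown here, no pair of measured compounds shows this same change, so there is no measured step to lean on. The expectation is that the step from compound 3 to compound 4 in this assay stays within the scatter, a number 5 percentage points higher from compound 3 to compound 4 (within the scatter), with no clear direction. Compound 4 is therefore estimated at 25% in this assay, with a range from 10% to 45%.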

Compound 4, a percentage reported as activity, at one dose (the size of the read-out at that dose, not a potency): 21%
Beside the measured number, compound 4's estimate is 4 percentage points above it, within the range that was stated.
By their numbers in this assay, from the lowest: compounds 1, 3, 4 and 2 (each within the scatter of the next, the first and the last beyond it).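

Replacing 6-methylpyridin-2-yl with quinolin-2-yl on the carbonyl carbon gives, in this assay, a number 1 percentage points higher from compound 3 to compound 4 (within the scatter) and so brings no clear change. This single step shows that a second aromatic ring in this group, one of carbon only, can be present without moving the read-out beyond the scatter. No measurement is available that bears on this result.

On these data alone, whether a group carrying an amine or a carboxylic acid in place of quinolin-2-yl would shift the number remains open. So does whether this change behaves alike on the shorter chain of compound 1.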